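The source may report more compounds than this note shows. Statements on the series, on what has been measured and on what is new or still open speak of the compounds shown alone.

Within the data shown here, compound 1 `O=C(Nc1cc(C(F)(F)F)cc(C(F)(F)F)c1)c1cc(Br)c(-c2ccccc2)cc1O` is the only one of three measured compounds to give a number in a functional assay on KG-1 cells (Homo sapiens) for cytotoxicity, read by luminescence and CellTiter-Glo, with a stated time of 3 days; a lower number here means a stronger inhibitor, a higher number a weaker inhibitor: compound 1 gives 300 nM. Compound 2 `COc1cccc(C(=O)Nc2ccc(C#N)cc2)c1O` reaches only a limit of the assay, not a number, as in this assay compound 2 gives > 10000 nM. Compound 3 `N#Cc1ccc(NC(=O)c2ccc[nH]c2=O)cc1` likewise stops at a limit, giving > 10000 nM in this assay. Compound 2 therefore stands at the limit of > 10000 nM in this assay, at which 2 of the 3 values shown sit, indistinguishable from compound 3 and far from compound 1. Compound 4 `Cc1cccc(C(=O)Nc2ccc(C#N)cc2)c1O` has not yet been measured. It differs from compound 2 in one place: methyl in place of methoxy on an aromatic carbon. The new group sits on an aromatic carbon of a six-membered aromatic ring of carbon only, ortho to a hydroxy group and meta to a large group. Among the measured compounds shown here, no measured pair shows what such a swap does. Since compound 2 sits at the limit of > 10000 nM in this assay, at which 2 of the 3 values shown sit, this change is expected to leave the result within the scatter, most likely at the limit again. Compound 4 is expected to give 12000 nM, within 4000 nM to 40000 nM, in this assay. The expected step that the limit leaves unreadable from compound 2 to compound 4 is none beyond the scatter.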

Compound 4, half-maximal inhibitory concentration: 8980 nM
For compound 4 the middle estimate is 1.3-fold (0.13 log units) above the measured one; the range from low to high includes it.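

With methyl in place of methoxy on an aromatic carbon ortho to a hydroxy group, compound 4 gives a readable number in this assay, 8980 nM, whereas compound 2 and compound 3 gave none. Compound 2 reaches only a limit of the assay: the limit of > 10000 nM in this assay, at which 2 of the 4 values shown sit.

The change therefore reads as an at least 1.1-fold lower number from compound 2 to compound 4 (0.04 log units; that floor lies within the scatter), so methyl is not shown to differ from methoxy at this position, and the true size of the step stays hidden behind the limit. Still open, from the compounds shown here alone, is whether another group at this position, such as an amine, a carboxylic acid or a longer chain like ethoxy, would move the number beyond the scatter. Also open, going by these compounds, is how the number would respond if the hydroxy group were removed while the methyl stayed in place.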